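The source may hold more compounds than are shown below. What is called first, only, known or untested is meant among the compounds shown, and "the series" means these compounds.

In a physicochemical assay for solubility, read by nephelometry, measured as kinetic solubility, at pH 2.0 (a lower number here means a less soluble compound, a higher number a more soluble compound), compound 3 `CC(C)(C)c1cc(C(=O)Nc2ccccc2)n(Cc2ccccc2)n1` gives 1.6 ug/mL, the lowest of the two plain numbers shown; the nearest is compound 2 `COc1ccc(C(=O)Nc2nc(CN)cs2)cc1`, which in this assay gives 50 ug/mL. Compound 1 `Cc1csc(NC(=O)c2cc(C(C)(C)C)nn2Cc2ccccc2)n1` gives only a limit of the assay, < 1.6 ug/mL. For the measured compounds named here, the single measured step that swaps the group on the amide-type nitrogen, phenyl in place of 4-methyl-1,3-thiazol-2-yl, reads a number no lower from compound 1 to compound 3 (the limit leaves the size open). Compound 4 `CC(C)(C)c1cc(C(=O)Nc2cccnc2)n(Cc2ccccc2)n1` differs from compound 3 in one place: pyridin-3-yl in place of phenyl on an amide-type nitrogen. Going by the values given here, no measured pair exchanges phenyl for pyridin-3-yl, so the change is largely unanchored; the only step touching this position was flat or upward. A modest rise in this assay is therefore expected, a 2.2-fold higher number from compound 3 to compound 4 (0.34 log units; beyond the scatter). Compound 4 is estimated at 3.5 ug/mL, within 1.6 ug/mL to 12 ug/mL.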

Compound 4, solubility: > 100 ug/mL
Compound 4 gave a limit, no number (the forecaster's own chance of this, stated with the estimate: 30%); at least 28-fold (1.45 log units) between middle value and limit.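

Swapping phenyl for pyridin-3-yl on the amide-type nitrogen moves this assay strongly, giving an at least 62-fold higher number from compound 3 to compound 4 (1.79 log units; beyond the scatter) while the rest of the molecule stays the same. Replacing 4-methyl-1,3-thiazol-2-yl gives an at least 62-fold higher number from compound 1 to compound 4 (1.79 log units; beyond the scatter) and so puts a readable large step at a position where the earlier step had no readable size. Compound 4 sits at a limit of the assay, so both sizes are minimums. From the compounds shown here alone, whether pyridin-4-yl or pyrimidin-5-yl on this nitrogen would match pyridin-3-yl stays open.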